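The compounds below may be only part of what the source reports. "The series", "measured", "known", "first", "only" and "open" are said of these compounds alone.

Measured in an assay on isolated protein for binding affinity to stress-70 protein, mitochondrial (Homo sapiens); on this read-out higher numbers stand for weaker binding and lower numbers for tighter binding:

Compound 1 `CC1(C)CCNc2ccc(NC(=O)Nc3ccc([N+](=O)[O-])cc3)cc21`: 1100 nM
Compound 2 `CC1(C)CC[N+](C)(C)c2ccc(NC(=O)Nc3ccc([N+](=O)[O-])cc3)cc21`: 700 nM
Compound 3 `CN1c2ccc(NC(=S)Nc3ccc([N+](=O)[O-])cc3)cc2C(C)(C)C(O)C1(C)C`: 2300 nM

Compound 3 stands at the highest number of the three in this assay. Compound 1 gives 1100 nM, a gap from compound 3 that lies beyond the scatter; compound 2 gives 700 nM, a wider gap, also beyond the scatter. All three share the urea or thiourea link to the nitro-bearing ring; only compound 3 carries the thiourea and the hydroxylated core.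

Compound 4 `CN1c2ccc(NC(=S)Nc3ccc(OC(F)(F)F)cc3)cc2C(C)(C)C(O)C1(C)C` differs from compound 3 in one place: trifluoromethoxy in place of nitro on an aromatic carbon. Within the data shown here, no measured pair shows this change, so there is no step to read the size or direction from. With nothing comparable among the measured compounds, the step of a 1.1-fold higher number from compound 3 to compound 4 (0.04 log units; within the scatter) is expected to be small, likely within the scatter, with the direction left open. In this assay compound 4 is estimated at 2500 nM, with a range from 1000 nM to 6000 nM.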

Compound 4, dissociation constant: 2900 nM
The estimate for compound 4 lay 1.2-fold (0.06 log units) below the measured number, and the stated range covers the measured number.
By their numbers in this assay, from the lowest: compounds 2 and 1 (each within the scatter of the next); then compounds 3 and 4 (each within the scatter of the next).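

Among these compounds, replacing nitro with trifluoromethoxy on an aromatic carbon, para to a large group, gives a 1.3-fold higher number from compound 3 to compound 4 (0.10 log units; within the scatter) in this assay, the first reading of any group other than nitro at this position. On the core shared by compound 3 and compound 4, nitro is therefore not needed to keep the binding reading at this level, and the two groups cannot be told apart in this assay. No supporting data are available to account for this match between the two groups.

Still open, as far as these compounds go, is whether a group of another kind on this aromatic carbon, such as an amine, a carboxylic acid or a longer alkoxy chain, would move the number beyond the scatter. From the compounds shown here alone, it is equally open whether the same exchange would read alike on the urea of compound 1.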